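The source may report more compounds than this note shows. Statements on the series, on what has been measured and on what is new or still open speak of the compounds shown alone.

In an ADME assay on J774.A1 cells (Mus musculus) for cytotoxicity, read by MTT assay, with a stated time of 48 h (a lower number here means that less compound is tolerated, a higher number that more compound is tolerated), compound 1 `COc1ccc(CNC(=O)c2c([N+](=O)[O-])noc2-c2ccc([N+](=O)[O-])cc2)cc1` gives 69600 nM and compound 2 `O=C(NCc1ccc(F)cc1)c1c([N+](=O)[O-])noc1-c1ccc(Cl)cc1` gives 91900 nM on the same read-out. These two numbers lie within the scatter of each other, so compound 2 cannot be told apart from compound 1 on the data so far, although the two differ in more than one place. Compound 3 `COc1ccc(CNC(=O)c2c([N+](=O)[O-])noc2-c2ccc(Cl)cc2)cc1` keeps all of compound 2 except for one group. It has methoxy in place of fluoro on an aromatic carbon, para to a large group, so the 4-fluorobenzyl becomes a 4-methoxybenzyl methoxy in place of fluoro on an aromatic carbon while the rest stays the same. For the measured compounds named here, no measured pair shows this change on its own, so its size cannot be read directly. Compound 1 already carries the 4-methoxybenzyl group and gives 69600 nM in this assay without standing apart from compound 2, so no step beyond the scatter is expected. The estimated step of a 1.1-fold lower number from compound 2 to compound 3 (0.06 log units; within the scatter) is therefore small. For compound 3 the expected value is 80000 nM with an estimated range from 40000 nM to 160000 nM around it.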

Compound 3, half-maximal cytotoxic concentration: 89500 nM
The estimate for compound 3 lay 1.1-fold (0.05 log units) below the measured number; measured number inside the range.
By their numbers in this assay, from the lowest: compounds 1, 3 and 2 (each within the scatter of the next).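

In this assay, the pair of compound 2 and compound 3 now isolates one exchange, methoxy in place of fluoro on an aromatic carbon, para to a large group, and gives a 1.0-fold lower number from compound 2 to compound 3 (0.01 log units; within the scatter), so the two groups cannot be told apart at this position in this read-out. Compound 3 also pairs with compound 1, isolating a second exchange, chloro in place of nitro on an aromatic carbon, which gives a 1.3-fold higher number from compound 1 to compound 3 (0.11 log units; within the scatter), so this exchange also produces no difference that can be told from the scatter. No independent measurement here offers an explanation for either result.

As far as these compounds go, these pairs test only fluoro against methoxy at the first position and nitro against chloro at the second, so it remains open whether an amine, a carboxylic acid or a longer chain such as butoxy at the position para to a large group would give a step beyond the scatter. The same question stands for changes to the shared core, which stays the same in all three compounds.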